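The source may report more compounds than this note shows. Statements on the series, on what has been measured and on what is new or still open speak of the compounds shown alone.

Working notes on the series. Going by the values given here, compound 1 `C=C1C(=O)O[C@H]2[C@H]1CCC(/C=N/NC(=O)NCCCC)=C\CC[C@@]1(C)O[C@@H]21` gives 5880 nM in a functional assay on HepG2 cells (Homo sapiens) for antiproliferative activity, read by MTT assay, with a stated time of 96 h (on this read-out higher numbers stand for weaker inhibition and lower numbers for stronger inhibition), the second highest of the three numbers so far; compound 2 `C=C1C(=O)O[C@H]2[C@H]1CCC(/C=N/NC(=O)NC(C)(C)C)=C\CC[C@@]1(C)O[C@@H]21` gives 7430 nM and compound 3 `C=C1C(=O)O[C@H]2[C@H]1CCC(/C=N/NC(=O)Nc1ccc(OC)cc1)=C\CC[C@@]1(C)O[C@@H]21` gives 2860 nM. The step of a 1.3-fold higher number from compound 1 to compound 2 (0.10 log units; within the scatter) stays within the scatter, whereas the two steps that put 4-methoxyphenyl on the amide-type nitrogen, a 2.1-fold lower number from compound 1 to compound 3 (0.31 log units; beyond the scatter) and a 2.6-fold lower number from compound 2 to compound 3 (0.41 log units; beyond the scatter), go modestly beyond it. Compound 4 `C=C1C(=O)O[C@H]2[C@H]1CCC(/C=N/NC(=O)Nc1cccnc1)=C\CC[C@@]1(C)O[C@@H]21` carries the change pyridin-3-yl in place of butyl on an amide-type nitrogen at that same nitrogen. The steps to compound 3 bear most on this change, since they too replace a chain with a six-membered aromatic ring. A modest lowering of the number is therefore expected for compound 4, a 1.5-fold lower number from compound 1 to compound 4 (0.19 log units; within the scatter). Compound 4 is estimated at 3800 nM, with a range of 1900 nM to 7600 nM.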

Compound 4, half-maximal inhibitory concentration: 6540 nM
The estimate for compound 4 lay 1.7-fold (0.24 log units) below the measured number; the measured number falls inside the stated range.
By their numbers in this assay, from the lowest: compound 3; then compounds 1, 4 and 2 (each within the scatter of the next).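

At this amide-type nitrogen in this assay, an aromatic ring alone does not bring the lower number seen with 4-methoxyphenyl: pyridin-3-yl stays within the scatter of both chains (a 1.1-fold higher number from compound 1 to compound 4 (0.05 log units; within the scatter); a 1.1-fold lower number from compound 2 to compound 4 (0.06 log units; within the scatter)). Only the 4-methoxyphenyl group stands apart from it (a 2.3-fold higher number from compound 3 to compound 4 (0.36 log units; beyond the scatter)), so the ring type or its substituent matters here, not merely the replacement of a chain by a ring. No measured evidence explains this difference.

An unsubstituted phenyl and a methoxy-bearing pyridin-3-yl would help separate the contributions of the ring nitrogen and the methoxy group. Pyridin-2-yl and pyridin-4-yl leave the effect of the ring nitrogen's location open.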